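The compounds below may be only part of what the source reports. "The series", "measured", "known", "first", "only" and "open" are said of these compounds alone.

Measured compounds:
compound 1, `COc1cc(Nc2ncnc3c(NC(=O)Nc4ccc(F)cc4C(F)(F)F)cccc23)cc(OC)c1`, 2970 nM
compound 2, `COc1cc(Nc2ncnc3c(NC(=O)Nc4ccc(C(F)(F)F)cc4[N+](=O)[O-])cccc23)cc(OC)c1`, > 20000 nM
compound 3, `COc1cc(Nc2ncnc3c(NC(=O)c4cccc(N5CCN(C)CC5)c4)cccc23)cc(OC)c1`, > 20000 nM

Of the compounds shown here, three sharing one core have been tested in a functional assay on RT-112 cells (Homo sapiens) for antiproliferative activity, read by MTT assay, with a stated time of 72 h; a lower number here means a stronger inhibitor of growth, a higher number a weaker inhibitor of growth. Compound 1 is the only one of the three with a number: in this assay compound 1 gives 2970 nM. Compound 2 gives > 20000 nM in this assay, and that is a limit, not a number. Compound 3 likewise gives > 20000 nM in this assay, again a limit. Thus the limit of > 20000 nM in this assay, at which 2 of the 3 values shown sit, holds for two of the three values, and no step between measured compounds can be followed.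

Compound 4, `COc1cc(Nc2ncnc3c(NC(=O)c4ccc(CN(C)C)cc4)cccc23)cc(OC)c1`, has not yet been measured in this assay. It differs from compound 1 in one place: 4-((dimethylamino)methyl)phenyl in place of (4-fluoro-2-(trifluoromethyl)phenyl)amino on a carbonyl carbon. Compound 3 also carries a substituted phenyl on that carbonyl carbon, so the nearest measured comparison sits at the limit. Compound 4 is therefore expected to lose potency in this assay, a step of a 5.1-fold higher number from compound 1 to compound 4 (0.70 log units; beyond the scatter), with a fair chance that only a limit is reported. For compound 4 the estimate is 15000 nM, within a range of 3000 nM to 40000 nM.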

Compound 4, concentration for 50% growth inhibition: 4370 nM
Compound 4: the middle estimate sits 3.4-fold (0.54 log units) above what was measured; the measured number falls inside the stated range.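

In this assay, 4-((dimethylamino)methyl)phenyl in place of (4-fluoro-2-(trifluoromethyl)phenyl)amino on a carbonyl carbon gives a 1.5-fold higher number from compound 1 to compound 4 (0.17 log units; within the scatter). A measurable number at this position therefore does not depend on the (4-fluoro-2-(trifluoromethyl)phenyl)amino group, and a phenyl joined directly to the carbonyl carbon can also give one. Compound 3, which also carries a substituted phenyl on that carbonyl carbon, gives > 20000 nM in this assay, a limit and not a number, so the substituent on that phenyl matters and the limit remains common among these compounds: the limit of > 20000 nM in this assay, at which 2 of the 4 values shown sit.

The compounds shown do not separate the contribution of the dimethylamino group from that of the phenyl that carries it. Going by these compounds, whether a morpholine or a primary amine in its place would give a similar number in this assay remains open.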